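This account rests on a few compounds, and the source may have more. Where it says the series, first, only, none or still open, it means among the compounds named here.

Measured compounds:

Compound 1, `CC(=O)OCc1ccc2oc(=O)c(C(=O)Oc3cccc(Cl)c3)cc2c1`, in a functional assay on HT-1080 cells (Homo sapiens), read by transwell migration, with a stated time of 24 h, tested at 10 uM (on this read-out lower numbers stand for a stronger effect and higher numbers for a weaker effect at the one concentration tested), compound 1 gives 6.17%.
Compound 2, `CCC(=O)OCc1ccc2oc(=O)c(C(=O)Oc3cccc(Br)c3)cc2c1`, in this assay compound 2 gives 21.3%.
Compound 3, `CCCC(=O)OCc1ccc2oc(=O)c(C(=O)Oc3cccc(Br)c3)cc2c1`, in this assay compound 3 gives 24.7%.

Compound 3 carries the top number of the three shown. Within the data shown here, compound 2 sits within the scatter of it, so the two cannot be separated on these data; compound 1 lies beyond the scatter below both, though compound 1 also differs from the others at the halogen, so no single step is drawn to it.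

The next compound, compound 4, `CCCCCCC(=O)OCc1ccc2oc(=O)c(C(=O)Oc3cccc(Br)c3)cc2c1`, is not yet measured. From compound 3 it differs by propyl in place of hydrogen on a saturated chain carbon, three bonds along the chain from a carbonyl carbon. Among the measured compounds shown here, the only measured step that bears on this is the chain lengthening a number 3.4 percentage points higher from compound 2 to compound 3 (within the scatter), which stayed within the scatter. A longer chain is added here, yet nothing in the measured series shows that a longer chain moves the number beyond the scatter. The expected step of a number 3.3 percentage points higher from compound 3 to compound 4 (within the scatter) is therefore small, if anything toward a higher number. Compound 4 is expected to give 28% in this assay, within a range from 14% to 44%.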

Compound 4, a percentage reported as activity, at one concentration (the size of the read-out at that concentration, not a potency): 36%
Beside the measured number, compound 4's estimate is 8 percentage points below it; the range from low to high includes it.
By their numbers in this assay, from the lowest: compound 1; then compounds 2 and 3 (each within the scatter of the next); then compound 4.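

Working notes on the chain: in this assay propyl in place of hydrogen on a saturated chain carbon, three bonds along the chain from a carbonyl carbon, gives a number 11.3 percentage points higher from compound 3 to compound 4 (beyond the scatter) and so passes the scatter, while the smaller methyl change gives a number 3.4 percentage points higher from compound 2 to compound 3 (within the scatter) and stays within it. The butyl change on the saturated chain carbon two bonds along the chain from a carbonyl carbon gives a number 14.7 percentage points higher from compound 2 to compound 4 (beyond the scatter) and thus shows that among compounds 2, 3 and 4 chain length can shift the read-out toward a weaker effect. No available evidence bears on the reason for this shift.

On these data alone, whether a longer chain than that of compound 4 would carry the trend further remains open, as does the outcome of ending the chain in an amine or a carboxylic acid. Compound 1 differs from the others at both the chain and the halogen, so the separate contribution of each remains unresolved.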